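This account rests on a few compounds, and the source may have more. Where it says the series, first, only, none or still open, it means among the compounds named here.

Measured compounds:
compound 1 `CC(C)c1onc(-c2c(Cl)cccc2Cl)c1COc1ccc(-c2cc3ccc(C(=O)O)nc3cc2F)cc1` — in a functional assay on CV-1 cells for agonist activity at Bile acid receptor (Homo sapiens), read by a luciferase reporter (a lower number here means that less compound is needed, a higher number that more compound is needed for the effect), compound 1 gives 110 nM
compound 2 `COc1cc(C(=O)O)nc2ccc(-c3ccc(OCc4c(-c5c(Cl)cccc5Cl)noc4C(C)C)cc3)cc12` — in this assay compound 2 gives 17 nM

Compound 2 stands as the lower of the two numbers; its gap to compound 1 lies beyond the scatter, so compound 2 is the more potent of the pair.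

Compound 3 `CC(C)Oc1cc(C(=O)O)nc2ccc(-c3ccc(OCc4c(-c5c(Cl)cccc5Cl)noc4C(C)C)cc3)cc12` differs from compound 2 by isopropyl in place of methyl on an oxygen on an aromatic ring. Going by the values given here, no comparable step has been measured, so the direction is open; a shift within or only just beyond the scatter is expected, if anything toward a slightly higher number. Compound 3 is expected to give 28 nM in this assay, in the range 9 nM to 90 nM. The expected step is a 1.6-fold higher number from compound 2 to compound 3 (0.22 log units; within the scatter).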

Compound 3, half-maximal effective concentration: 14 nM
Beside the measured number, compound 3's estimate is 2.0-fold (0.30 log units) above it; the measured number falls inside the stated range.
By their numbers in this assay, from the lowest: compounds 3 and 2 (each within the scatter of the next); then compound 1.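

Isopropyl in place of methyl on an oxygen on an aromatic ring gives a 1.2-fold lower number from compound 2 to compound 3 (0.08 log units; within the scatter) in this assay. Going by these compounds alone, as the first one-place step, it shows that this position accepts isopropoxy as well as methoxy with no shift beyond the scatter. Nothing available accounts for this result.

Still open, as far as these compounds go, is whether a longer chain on the oxygen, such as n-butyl, would keep the number within the scatter. A hydroxyl or an amine at this place is also untested among the compounds shown.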